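The source may hold more compounds than are shown below. What is called first, only, known or untested is meant among the compounds shown, and "the series" means these compounds.

Two compounds have been measured in a functional assay on MCF7 cells (Homo sapiens) for cytotoxicity, read by MTT assay, with a stated time of 24 h, tested at 6.4 ug/mL; on this read-out higher numbers stand for a stronger effect at the one concentration tested and lower numbers for a weaker effect:

Compound 1, `Cn1c(-c2ccc(NC(=O)CSc3nc4cc(Cl)ccc4o3)cc2)nc(-c2ccccc2)c1-c1ccccc1`, gives 27.7%.
Compound 2, `Cn1c(-c2ccc(NC(=O)CSc3nc4ccccc4s3)cc2)nc(-c2ccccc2)c1-c1ccccc1`, gives 27%.

Compound 2 stands alongside compound 1: the step of a number 0.7 percentage points lower from compound 1 to compound 2 (within the scatter) lies within the scatter, so neither compound can be called stronger or weaker than the other on these numbers. Compound 3, `Cn1c(-c2ccc(NC(=O)CSC3=NCCS3)cc2)nc(-c2ccccc2)c1-c1ccccc1`, has not yet been measured. It differs from compound 2 in one place: a group of 5 heavy atoms (3 carbon, 1 nitrogen, 1 sulfur; one five-membered non-aromatic ring with 2 hetero atoms) in place of a group of 9 heavy atoms (7 carbon, 1 nitrogen, 1 sulfur; one five-membered aromatic ring with 2 hetero atoms, one six-membered aromatic ring of carbon only), on a sulfur. For the measured compounds named here, only one measured step bears on this kind of change, the exchange of one ring group for another on the same sulfur, and that step, a number 0.7 percentage points lower from compound 1 to compound 2 (within the scatter), was too small to count. The change to compound 3 goes further, replacing a group with two aromatic rings by a single five-membered non-aromatic ring, and nothing measured shows what that does. The expected step is therefore small and of uncertain direction, a number 2 percentage points lower from compound 2 to compound 3 (within the scatter), with a wide margin around it. Compound 3 is estimated to give 25% in this assay, within a range from 13% to 37%.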

Compound 3, a percentage reported as activity, at one concentration (the size of the read-out at that concentration, not a potency): 18.6%
Compound 3: middle estimate off by 6.4 percentage points, on the high side; measured number inside the range.
By their numbers in this assay, from the lowest: compounds 3, 2 and 1 (each within the scatter of the next).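

Replacing 1,3-benzothiazol-2-yl on the sulfur with a five-membered non-aromatic ring gives a number 8.4 percentage points lower from compound 2 to compound 3 (within the scatter) in this assay, and the same ring in place of 5-chloro-1,3-benzoxazol-2-yl gives a number 9.1 percentage points lower from compound 1 to compound 3 (within the scatter) on the same read-out. The earlier step compared two groups that each hold a five-membered aromatic ring and a six-membered aromatic ring of carbon only, whereas these two steps show that this read-out at the one concentration tested stays within the usual scatter even when the sulfur carries no aromatic ring at all. No measurement is available that explains these numbers.

The three compounds share one core and differ only in the ring group on the sulfur, so they leave open what a group of a different kind at this place would do, such as an amine, a carboxylic acid or a plain alkyl chain. Since each number comes from a single concentration, they also leave open how these compounds would compare across a range of concentrations.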